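A few compounds are considered here, and "the series" means these few. Any claim that something is new, unique, unknown or untested is made for them only; others in the source may bear on it.

Measured so far in a functional assay on CHO cells with metabotropic glutamate receptor 2 (Homo sapiens) as the target, read by GTPgammaS binding; on this read-out higher numbers stand for an effect only at larger amounts of compound and lower numbers for an effect already at smaller amounts:
compound 1, `CCCc1cnc2c(C#N)c(N3CCN(c4ncccn4)CC3)ccn12`: > 3160 nM
compound 2, `CC(C)(C)c1ccc(-c2ccn3c(CC(F)(F)F)cnc3c2C#N)cc1`: 447 nM

Compound 1 did not yield a number; in this assay compound 1 gives > 3160 nM, which is a limit of the assay. Among the compounds with values here, compound 2 is the one compound with an actual value: in this assay compound 2 gives 447 nM. It therefore stands as the single point of reference, since the second reading sits at the limit of > 3160 nM in this assay, at which 1 of the 2 values shown sits, rather than at a number.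

Compound 3, `N#Cc1c(-c2ccc(N3CCCCC3)cc2)ccn2c(CC(F)(F)F)cnc12`, has not been measured. It differs from compound 2 in one place: piperidin-1-yl in place of tert-butyl on an aromatic carbon. Within the data shown here, no measured pair shows what such an exchange does in this assay, so the expectation rests on compound 2 alone. The step from compound 2 to compound 3 is expected to be small, of about the size of the usual scatter or only a little beyond it, with no firm direction, and a 1.4-fold lower number from compound 2 to compound 3 (0.15 log units; within the scatter) expresses this expectation. Compound 3 is accordingly expected to give about 320 nM in this assay, with a plausible range from 80 nM to 1300 nM.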

Compound 3, half-maximal effective concentration: 234 nM
Estimate against measurement, compound 3: 1.4-fold (0.14 log units) above; measured number inside the range.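

In this assay, the exchange of tert-butyl for piperidin-1-yl on the aromatic carbon, para to a large group, gives a 1.9-fold lower number from compound 2 to compound 3 (0.28 log units; within the scatter). Within the data shown here, this is the first measured step at this place, and it shows that the place takes a group with a six-membered non-aromatic ring and a nitrogen atom as well as a branched group with carbon only, since compound 2 and compound 3 cannot be told apart on this read-out. The values shown give no reason for this outcome, and with a single pair nothing can be said about what the hydrogen-bond acceptor or the ring adds.

Both groups shown carry no net charge and no hydrogen-bond donor, so it remains open whether a carboxylic acid, a primary amine or a hydroxyl group would be taken equally well at this place. On these data alone, it is also open whether a simple methyl group or a hydrogen atom there would hold the reading, or whether a morpholine ring would behave like piperidin-1-yl.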